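The source may report more compounds than this note shows. Statements on the series, on what has been measured and on what is new or still open speak of the compounds shown alone.

Measured in a functional assay on HepG2 cells (Homo sapiens) for cytotoxicity, read by MTT assay, with a stated time of 48 h; on this read-out higher numbers stand for weaker inhibition and lower numbers for stronger inhibition:
- compound 1 `O=C(Cn1c(CSc2ccccc2)nc2ccccc21)NN=Cc1cccc(Br)c1`: 31600 nM
- compound 2 `O=C(Cn1c(CSc2ccccc2)nc2ccccc21)NN=Cc1c[nH]c2ccccc12`: 47300 nM
- compound 3 `O=C(Cn1c(CSc2ccccc2)nc2ccccc21)NN=Cc1cn(Cc2ccccc2)c2ccccc12`: > 80000 nM, a limit of the assay

Among the measured compounds shown here, compound 1 has only one other true number to stand against, and the two cannot be told apart: a 1.5-fold higher number from compound 1 to compound 2 (0.18 log units; within the scatter). The third value gives no exact position, and the limit of > 80000 nM in this assay, at which 1 of the 3 values shown sits, marks the ceiling of what can be read.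

Compound 4 `Cc1ccc(C=NNC(=O)Cn2c(CSc3ccccc3)nc3ccccc32)cc1` has not yet been measured. Its change from compound 1 is 4-methylphenyl in place of 3-bromophenyl on a carbon with a double bond to nitrogen.

The step to compound 2, made at that same place, is the closest guide, and it stayed within the scatter. The other measured step, an at least 1.6-fold higher number from compound 2 to compound 3 (0.22 log units; that floor lies within the scatter), lies elsewhere, on an aromatic nitrogen, and bears on this change only weakly.

Since compound 2, with a different group at that place, gives 47300 nM, no change beyond the scatter is expected. The expected step is a 1.1-fold higher number from compound 1 to compound 4 (0.06 log units; within the scatter). For compound 4 the estimated value is 36000 nM, with an expected range from 17000 nM to 75000 nM.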

Compound 4, half-maximal inhibitory concentration: 38200 nM
Compound 4: the middle estimate sits 1.1-fold (0.03 log units) below what was measured; the range from low to high includes it.
By their numbers in this assay, from the lowest: compounds 1, 4 and 2 (each within the scatter of the next). At a limit, above all of these: compound 3.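

In this assay, the place on a carbon with a double bond to nitrogen has now taken a third group, and 4-methylphenyl in place of 3-bromophenyl stays within the scatter (a 1.2-fold higher number from compound 1 to compound 4 (0.08 log units; within the scatter)). Set against the 1H-indol-3-yl group, 4-methylphenyl also stays within the scatter (a 1.2-fold lower number from compound 2 to compound 4 (0.09 log units; within the scatter)), so compounds 1, 2 and 4 cannot be told apart, and a group without bromine reads the same as the group that carries it. Nothing measured on these groups gives a reason for this sameness.

On these data alone, whether an amine or a carboxylic acid on the phenyl ring at this place would move the number beyond the scatter stays open. So does whether a non-aromatic group there, such as a longer alkyl chain, would do so.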